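The source may hold more compounds than are shown below. What is called first, only, known or untested is meant among the compounds shown, and "the series" means these compounds.

Compound 1 `Cc1ccc(C(=O)Nc2cccc(-c3oc4cc(-c5ccc(F)cc5)ccc4c(=O)c3O)c2)cc1`: 12900 nM
Compound 2 `O=C(Nc1cccc(-c2oc3cc(-c4ccc(F)cc4)ccc3c(=O)c2O)c1)c1ccc(Cl)cc1`: 9140 nM
Compound 3 `COc1ccccc1C(=O)Nc1cccc(-c2oc3cc(-c4ccc(F)cc4)ccc3c(=O)c2O)c1`: 6370 nM

Among these three, all measured in a functional assay on GTL 16 cells for antiproliferative activity against GTL 16 cell line (Homo sapiens), read by CCK-8 assay, with a stated time of 72 h (on this read-out higher numbers stand for weaker inhibition and lower numbers for stronger inhibition), compound 3 gives the lowest number. The narrower of its two gaps is a 1.4-fold lower number from compound 2 to compound 3 (0.16 log units; within the scatter), and the wider one is a 2.0-fold lower number from compound 1 to compound 3 (0.31 log units; beyond the scatter). Compound 4 `Cc1ccccc1C(=O)Nc1cccc(-c2oc3cc(-c4ccc(F)cc4)ccc3c(=O)c2O)c1` differs from compound 3 by methyl in place of methoxy on an aromatic carbon, so 2-methoxyphenyl becomes 2-methylphenyl on the carbonyl carbon. For the measured compounds named here, no measured step makes exactly this change: the step of a 2.0-fold lower number from compound 1 to compound 3 (0.31 log units; beyond the scatter) exchanges methyl for methoxy but also alters the substitution pattern, and a 1.4-fold lower number from compound 1 to compound 2 (0.15 log units; within the scatter) shows that swapping one small group for another on that ring moves the number little. A small rise in the number, if any, is therefore expected, about a 1.4-fold higher number from compound 3 to compound 4 (0.15 log units; within the scatter). Compound 4 is estimated at 9000 nM, between 4000 nM and 20000 nM.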

Compound 4, half-maximal inhibitory concentration: 24800 nM
The estimate for compound 4 lay 2.8-fold (0.44 log units) below the measured number; the measured number lies above the stated range.
By their numbers in this assay, from the lowest: compounds 3, 2, 1 and 4 (each within the scatter of the next, the first and the last beyond it).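

Swapping 2-methoxyphenyl for 2-methylphenyl on the carbonyl carbon is a larger change than the earlier compounds suggested: in this assay methyl in place of methoxy gives a 3.9-fold higher number from compound 3 to compound 4 (0.59 log units; beyond the scatter) and so this site, ortho to a large group, is sensitive to which small group it carries. The comparison with the chloro compound gives a 2.7-fold higher number from compound 2 to compound 4 (0.43 log units; beyond the scatter) while the step of a 1.9-fold higher number from compound 1 to compound 4 (0.28 log units; within the scatter) stays within the scatter, so moving the methyl group shows no clear effect. No measurement here accounts for the gap between methoxy and methyl. Going by these compounds, whether 2-hydroxyphenyl or 2-aminophenyl would behave more like 2-methoxyphenyl or 2-methylphenyl remains open.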